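The source may report more compounds than this note shows. Statements on the series, on what has been measured and on what is new or still open speak of the compounds shown alone.

Compound 1 `CCCCCCCOc1ccc(CCC(N)(CO)CCC)cc1` was tested in a functional assay on the whole organism (T-cell) with Rattus norvegicus as the target, with a stated time of 4 days (on this read-out higher numbers stand for an effect only at larger amounts of compound and lower numbers for an effect already at smaller amounts), where compound 1 gives 7.3 mg/kg. Of the two plain numbers shown, compound 1 stands at the upper one, though its nearest neighbour, compound 2 `CCCCCCCOc1ccc(CCC(N)(CO)C(C)C)cc1`, with 4.5 mg/kg, lies only a step of a 1.6-fold lower number from compound 1 to compound 2 (0.21 log units; within the scatter) away, within the scatter. Compound 3 `CCCCCCCOc1ccc(CC[C@](N)(CO)CCC)cc1` reaches only a limit of the assay, > 10 mg/kg. Compound 4 `CCCCCCCOc1ccc(CCC(N)(CC)CO)cc1` differs from compound 1 by hydrogen in place of methyl on a saturated chain carbon, three bonds along the chain from an amine nitrogen, that is, propyl to ethyl. Going by the values given here, the step from compound 1 to compound 2 is the one measured change of the same chain, and it stayed within the scatter; the step of an at least 2.2-fold higher number from compound 2 to compound 3 (0.34 log units; beyond the scatter) rests on a limit and a drawn configuration and says little here. The change to compound 4 is therefore expected to shift the number no further than the scatter, no change at the digits printed from compound 1 to compound 4 (within the scatter). Compound 4 is estimated at 7.3 mg/kg, between 3.5 mg/kg and 15 mg/kg.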

Compound 4, dose for 50% inhibition: 0.044 mg/kg
For compound 4 the middle estimate is 170-fold (2.22 log units) above the measured one; measured number outside the range, below it.
By their numbers in this assay, from the lowest: compound 4; then compounds 2 and 1 (each within the scatter of the next). At a limit, above all of these: compound 3.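

Going from propyl to ethyl on this carbon, three bonds along the chain from the amine nitrogen, gives a 170-fold lower number from compound 1 to compound 4 (2.22 log units; beyond the scatter), so this chain is far more sensitive to its exact form than the earlier within-scatter change from propyl to isopropyl showed. Ethyl also stands well clear of the isopropyl chain: a 100-fold lower number from compound 2 to compound 4 (2.01 log units; beyond the scatter). A third step, an at least 220-fold lower number from compound 3 to compound 4 (2.35 log units; beyond the scatter), starts from a limit and so gives only a floor: the limit of > 10 mg/kg in this assay, at which 1 of the 4 values shown sits.

The compounds shown leave open how a methyl or a butyl chain at this carbon would read. They also give no reason why the ethyl chain differs so sharply from the propyl chain.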